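The compounds below may be only part of what the source reports. "The series", "measured", "known", "first", "only" and "open" are said of these compounds alone.

Compound 1 `O=C(NCC1CCN(CCCS(=O)(=O)N2CCN(Cc3cccnc3)CC2)CC1)c1cccc2c1OCCO2` gives 0.159 nM in an assay on isolated protein for inhibition of 5-hydroxytryptamine receptor 4 (Homo sapiens) (a higher number here means a weaker inhibitor, a lower number a stronger inhibitor), and stands highest of the two numbers in hand. Compound 2 `CCCS(=O)(=O)N1CCN(S(=O)(=O)CCCN2CCC(CNC(=O)c3cccc4c3OCCO4)CC2)CC1` gives 0.1 nM in this assay. Among the measured compounds shown here, the one measured step at that ring nitrogen, a 1.6-fold lower number from compound 1 to compound 2 (0.20 log units; within the scatter), stays within the scatter. Compound 3 `CC(=O)N1CCN(S(=O)(=O)CCCN2CCC(CNC(=O)c3cccc4c3OCCO4)CC2)CC1` has not yet been measured; it differs from compound 1 by acetyl in place of (pyridin-3-yl)methyl on an amine nitrogen in a ring. For the measured compounds named here, because the only step at this position, a 1.6-fold lower number from compound 1 to compound 2 (0.20 log units; within the scatter), was within the scatter, no change beyond the scatter is expected here either. Compound 3 is therefore estimated at 0.15 nM, between 0.05 nM and 0.5 nM, an expected step of a 1.1-fold lower number from compound 1 to compound 3 (0.03 log units; within the scatter).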

Compound 3, inhibition constant: 0.126 nM
Compound 3: the middle estimate sits 1.2-fold (0.08 log units) above what was measured, within the range that was stated.
By their numbers in this assay, from the lowest: compounds 2, 3 and 1 (each within the scatter of the next).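

At this amine nitrogen in a ring, acetyl joins propylsulfonyl and (pyridin-3-yl)methyl as a third group that leaves the number in this assay essentially in place: the exchange for (pyridin-3-yl)methyl gives a 1.3-fold lower number from compound 1 to compound 3 (0.10 log units; within the scatter), and the exchange for propylsulfonyl gives a 1.3-fold higher number from compound 2 to compound 3 (0.10 log units; within the scatter). The position therefore accepts acetyl, with no ring and only 3 heavy atoms, as well as a group carrying a six-membered aromatic ring, with no step beyond the scatter among these three compounds. Nothing available bears on the reason for this result. From the compounds shown here alone, whether an unsubstituted ring nitrogen, a carboxylic acid or a longer chain at this position would also stay within the scatter remains open.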